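Moving Two Carbons Around a Phenyl Ring

The source may report more compounds than this note shows. Statements on the series, on what has been measured and on what is new or still open speak of the compounds shown alone.

Of the compounds shown here, two sharing one core have been tested in a functional assay on NCI-H520 cells (Homo sapiens) for inhibition, read by MTT assay, with a stated time of 48 h, tested at 10 uM; a lower number here means less inhibition, a higher number more inhibition at the concentration tested (going by the name of the read-out). Compound 1 `CCc1ccc(Nc2cc(NC(=O)Nc3c(Cl)cccc3Cl)ncn2)cc1` gives 31.5% in this assay, the lower of the two numbers. Compound 2 `COc1cc(Nc2cc(NC(=O)Nc3c(Cl)cccc3Cl)ncn2)cc(OC)c1` gives 55.5% in this assay, which stands above compound 1 by more than the usual scatter. The untested compound 3 `Cc1ccc(Nc2cc(NC(=O)Nc3c(Cl)cccc3Cl)ncn2)cc1C` differs from compound 1 only in how the same atoms are arranged: 3,4-dimethylphenyl in place of 4-ethylphenyl on a nitrogen on an aromatic ring. Within the data shown here, with no measured pair showing what such a rearrangement does, the only guide is that both measured compounds keep the same core and differ at this one position. The step from compound 1 to compound 3 is expected to be small, a number 4.5 percentage points higher from compound 1 to compound 3 (within the scatter), and could fall either way within the scatter. Compound 3 is therefore estimated at 36% in this assay, with a range from 15% to 60%.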

Compound 3, a percentage reported as inhibition, at one concentration (the size of the read-out at that concentration, not a potency): 47.5%
Beside the measured number, compound 3's estimate is 11.5 percentage points below it; measured number inside the range.
By their numbers in this assay, from the lowest: compound 1; then compounds 3 and 2 (each within the scatter of the next).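

Rearranging the same carbons from 4-ethylphenyl to 3,4-dimethylphenyl gives a number 16 percentage points higher from compound 1 to compound 3 (beyond the scatter) in this assay. The two groups match in every count computed for them, from heavy atoms to rings, so the number at this position depends on how the carbons are arranged and not only on which atoms are present. Nothing available explains why this arrangement gives more inhibition at the concentration tested.

The compounds shown leave open whether the step comes from losing the ethyl chain or from having two separate methyl groups on the ring, a question that phenyl groups carrying a single methyl or a longer propyl chain could help to settle. They also leave open how this position would respond to an amine or a carboxylic acid on the same ring.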